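Chloro for fluoro at the half-life limit

The source may hold more compounds than are shown below. What is called first, only, known or untested is meant among the compounds shown, and "the series" means these compounds.

In a physicochemical assay for pharmacokinetics (on this read-out higher numbers stand for a longer-lived compound and lower numbers for a shorter-lived compound), compound 2 (`O=C(NCc1ccccc1F)N1C(=O)c2ccccc2S1(=O)=O`) gives > 166 h and this is a limit, not a number. Compound 1 (`O=C(NCc1ccccc1Br)N1C(=O)c2ccccc2S1(=O)=O`) gives > 166 h and that too is a limit. Among the measured compounds shown here, the one measured step bearing on the change is a step that the two limits leave unreadable from compound 1 to compound 2 and it offers no size to carry over. Compound 3 (`O=C(NCc1ccccc1Cl)N1C(=O)c2ccccc2S1(=O)=O`) differs from compound 2 by chloro in place of fluoro on an aromatic carbon (chloro in place of fluoro, ortho to a large group). The measured compounds share only the limit of > 166 h in this assay, at which 2 of the 2 values shown sit, and this gives no direction. The expected step is a step that the limit leaves unreadable from compound 2 to compound 3 and it is not expected to exceed the scatter in this assay at all. Compound 3 is estimated at 250 h with an expected range of 140 h to 450 h for now.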

Compound 3, half-life: > 166 h
Compound 3: only a limit was reported (the forecaster's own chance of this, stated with the estimate: 85%); the middle value does not contradict the limit.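

In this assay compound 3 gives > 166 h, which is a limit, and its steps to compound 1 and compound 2 cannot be read. The compounds shown leave open whether bromo, chloro and fluoro differ at all in this assay.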